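The compounds below may be only part of what the source reports. "The series", "measured", "known", "first", "only" and "open" are said of these compounds alone.

Measured so far in a functional assay on MCF7 cells (Homo sapiens) for antiproliferative activity, read by MTT assay, with a stated time of 48 h; a higher number here means a weaker inhibitor, a lower number a stronger inhibitor:
- compound 1 `COc1cccc(C(=O)Nc2nnc(/C=C/c3cc(OC)c(OC)c(OC)c3Br)s2)c1`: 170 nM
- compound 2 `COc1cccc(C(=O)Nc2nnc(/C=C/c3cc(OC)c(OC)c(OC)c3)s2)c1`: 480 nM
- compound 3 `COc1cccc(/C=C/c2nnc(NC(=O)c3cc(OC)c(OC)c(OC)c3Br)s2)c1`: 590 nM

Compound 1 has the lowest of these three numbers, so it is the strongest inhibitor of the set. Both other compounds lie beyond the usual scatter from it. The next compound to be tested is compound 4 `COc1cc(/C=C/c2nnc(NC(=O)c3ccccc3)s2)c(Br)c(OC)c1OC`, which keeps the bromo group of compound 1 and differs from it in one place: hydrogen in place of methoxy on an aromatic carbon. In words, this is hydrogen in place of methoxy on an aromatic carbon, so 3-methoxyphenyl becomes phenyl.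

Among the compounds with values here, no measured step makes this exact change. Within the data shown here, the only single-place step available is a 2.8-fold higher number from compound 1 to compound 2 (0.45 log units; beyond the scatter), a modest change that concerns the bromo group and not the methoxy group. It shows only that one small substitution in this series can move the number beyond the scatter. Compound 3 is not linked to compound 1 by a single-place step, so it offers no direct guide.

A small rise in this assay seems the likelier direction because compound 1 at 170 nM is the lowest of the three numbers, though this is a weak argument. The expected step is a 1.8-fold higher number from compound 1 to compound 4 (0.25 log units; within the scatter), and it is uncertain. For compound 4 the estimated value is 300 nM, with an expected range from 90 nM to 1000 nM.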

Compound 4, half-maximal inhibitory concentration: 290 nM
The estimate for compound 4 lay 1.0-fold (0.01 log units) above the measured number, within the range that was stated.
By their numbers in this assay, from the lowest: compounds 1, 4, 2 and 3 (each within the scatter of the next, the first and the last beyond it).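

Replacing 3-methoxyphenyl with phenyl gives a 1.7-fold higher number from compound 1 to compound 4 (0.23 log units; within the scatter) in this assay, so the two compounds cannot be told apart and the methoxy group at this place is not shown to matter for the read-out. Within the data shown here, the earlier compounds offered no single-place comparison at this position; their only such step concerned the bromo group on the other aromatic ring, a 2.8-fold higher number from compound 1 to compound 2 (0.45 log units; beyond the scatter), and that step is printed as beyond the scatter, so this series now holds one single-place change that registers and one that does not. No measurement is available that could explain this result.

The compounds shown carry only methoxy or hydrogen at this place, which leaves open how an amine, a carboxylic acid or a longer chain such as butoxy would read there in this assay. Also open, from the compounds shown here alone, is whether the same swap of 3-methoxyphenyl for phenyl would read the same way in a compound without the bromo group, such as compound 2.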